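The source may hold more compounds than are shown below. What is called first, only, known or untested is meant among the compounds shown, and "the series" means these compounds.

Of the compounds shown here, three that share one core have so far been tested in a functional assay on HepG2 cells (Homo sapiens) for cytotoxicity, read by MTT assay; on this read-out lower numbers stand for stronger inhibition and higher numbers for weaker inhibition. Compound 1 `Cc1nc2c(s1)C(=O)C=C(Nc1cccc(Cl)c1)C2=O` gives 5.7 ug/mL in this assay. Compound 2 `Cc1nc2c(s1)C(=O)C=C(Nc1ccc(C)c(C)c1)C2=O` gives 4.8 ug/mL in this assay, and compound 3 `O=C1C=C(Nc2ccc(Cl)cc2)C(=O)c2scnc21` gives 16.4 ug/mL in this assay. Among these three numbers compound 1 stands second highest. Its nearest neighbour is compound 2, whose number lies within the usual scatter of that of compound 1, so no order between the two can be claimed. Compound 3 stands furthest away, with a number beyond the scatter and higher than that of compound 1. Within the data shown here, no single-point step between any two of the measured compounds is available, so nothing more than these pairwise readings can be drawn from them.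

Compound 4 `Cc1nc2c(s1)C(=O)C=C(Nc1cccc(Br)c1)C2=O` has not yet been measured. It differs from compound 1 by bromo in place of chloro on an aromatic carbon. Among the measured compounds shown here, no measured pair shows what this exchange does to the number in this assay, so the expectation rests on the small spread seen among the three measured compounds and on the small size of the change. The step of a 1.0-fold lower number from compound 1 to compound 4 (0.02 log units; within the scatter) is expected to lie within the scatter, in no fixed direction. Compound 4 is therefore estimated at 5.5 ug/mL in this assay, with a range from 2.7 ug/mL to 11 ug/mL.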

Compound 4, half-maximal inhibitory concentration: 15 ug/mL
Compound 4: middle estimate off by 2.7-fold (0.44 log units), on the low side; measured number above the stated range.
By their numbers in this assay, from the lowest: compounds 2 and 1 (each within the scatter of the next); then compounds 4 and 3 (each within the scatter of the next).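

In this assay, bromo in place of chloro on an aromatic carbon, meta to a large group, gives a 2.6-fold higher number from compound 1 to compound 4 (0.42 log units; beyond the scatter), which means weaker inhibition. Among these compounds, this is the first step that changes a single place, and it shows that this position is sensitive to the exchange of one halogen for another, even though one heavy atom leaves, one enters and the counts of hydrogen-bond donors and acceptors stay the same. No measurement at hand accounts for this step, so its cause remains unassigned.

Going by these compounds, whether other groups at this position, such as fluoro, methoxy, an amine or a carboxylic acid, would stay close to compound 1 or shift the number as bromo does remains open. Also open, on these data alone, is whether bromo in place of chloro would have a similar effect elsewhere on the aromatic ring, as this single step at a single position establishes no wider pattern.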